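Lengthening an Ester Chain One Carbon at a Time

A few compounds are considered here, and "the series" means these few. Any claim that something is new, unique, unknown or untested is made for them only; others in the source may bear on it.

The three measured compounds share one core and differ only in the length of the chain that carries an ethyl ester. Compound 1 `CCOC(=O)CCCCCNC(=O)N1c2c(O)nc(N)nc2NCC1CNc1ccc(C(=O)NC(CCC(=O)O)C(=O)O)cc1` gives 13 uM in a functional assay on HEp-2 cells (Homo sapiens), read by colony formation; a higher number here means that more compound is needed for the effect, a lower number that less compound is needed. Compound 2 `CCOC(=O)CCCCCCNC(=O)N1c2c(O)nc(N)nc2NCC1CNc1ccc(C(=O)NC(CCC(=O)O)C(=O)O)cc1` gives 4 uM, and compound 3 `CCOC(=O)CCCCCCCNC(=O)N1c2c(O)nc(N)nc2NCC1CNc1ccc(C(=O)NC(CCC(=O)O)C(=O)O)cc1` gives 24 uM, the highest number of the three. The unmeasured compound 4 `CCOC(=O)CCCCCCCCNC(=O)N1c2c(O)nc(N)nc2NCC1CNc1ccc(C(=O)NC(CCC(=O)O)C(=O)O)cc1` takes one more step along the same path: (ethoxycarbonyl)methyl in place of ethoxycarbonyl on a saturated chain carbon, seven bonds along the chain from an amide-type nitrogen. The two earlier steps of this kind pulled in opposite directions, a 3.3-fold lower number from compound 1 to compound 2 (0.51 log units; beyond the scatter) and a 6.0-fold higher number from compound 2 to compound 3 (0.78 log units; beyond the scatter), while a 1.8-fold higher number from compound 1 to compound 3 (0.27 log units; within the scatter). With no steady direction to lean on, compound 4 is expected to give an estimated 15 uM, within a range from 4 uM to 60 uM. That estimate means an expected 1.6-fold lower number from compound 3 to compound 4 (0.20 log units; within the scatter).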

Compound 4, concentration for half-maximal effect: 35 uM
The estimate for compound 4 lay 2.3-fold (0.37 log units) below the measured number; measured number inside the range.
By their numbers in this assay, from the lowest: compound 2; then compounds 1, 3 and 4 (each within the scatter of the next, the first and the last beyond it).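

The added carbon does not act the same way everywhere on this chain, since a 1.5-fold higher number from compound 3 to compound 4 (0.16 log units; within the scatter) while the earlier step went the other way: the same change on two cores in this assay, a 3.3-fold lower number (0.51 log units; beyond the scatter) from compound 1 to compound 2 and a 1.5-fold higher number (0.16 log units; within the scatter) from compound 3 to compound 4, 4.7-fold (0.68 log units) apart, beyond the scatter of two such steps

Adding two carbons likewise depends on the starting chain: the same change on two cores in this assay, a 1.8-fold higher number (0.27 log units; within the scatter) from compound 1 to compound 3 and an 8.8-fold higher number (0.94 log units; beyond the scatter) from compound 2 to compound 4, 4.7-fold (0.68 log units) apart, beyond the scatter of two such steps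

The longest chain also gives an 8.8-fold higher number from compound 2 to compound 4 (0.94 log units; beyond the scatter) and a 2.7-fold higher number from compound 1 to compound 4 (0.43 log units; beyond the scatter), so the low number belongs to a single chain length among these compounds, not to long chains in general.

Going by these compounds, whether a still longer chain would stay in this range remains open. So does whether a carboxylic acid in place of the ethyl ester would keep the low number of compound 2.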